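The compounds below may be only part of what the source reports. "The series", "measured", "known", "first", "only" and "open" are said of these compounds alone.

Compound 1 `Cc1cc(C#N)cc(C)c1Nc1ccnc(Nc2ccc(C#N)cc2)n1` and compound 3 `Cc1cc(C#N)cc(C)c1Nc1nc(Nc2ccc(C#N)cc2)ncc1Br` share a core, and in a physicochemical assay for lipophilicity (a lower number here means a more polar compound, a higher number a more lipophilic compound), compound 1 gives 1.21 while compound 3 gives 1.39. The change between them, (bromo in place of hydrogen on an aromatic carbon), made a step of a number 0.18 log units higher from compound 1 to compound 3 (within the scatter). Compound 2 `Cc1cc(C)c(Oc2ccnc(Nc3ccc(C#N)cc3)n2)c(C)c1` has a different core; how its core differs from that of compound 1 is not broken down here. In this assay compound 2 gives 1.82. Compound 4 `Cc1cc(C)c(Oc2nc(Nc3ccc(C#N)cc3)ncc2Br)c(C)c1` carries the same kind of change on the core of compound 2, (bromo in place of hydrogen on an aromatic carbon); here the place is para to a group of 9 heavy atoms, where in compound 3 it is para to a (4-cyanophenyl)amino group (9 heavy atoms). The step from compound 2 to compound 4 is expected to be a number 0.18 log units higher from compound 2 to compound 4 (within the scatter), because a number 0.18 log units higher from compound 1 to compound 3 (within the scatter) was seen between compound 1 and compound 3. Compound 4 is therefore estimated at 2.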

Compound 4, partition coefficient: 1.82
Beside the measured number, compound 4's estimate is 0.18 log units above it; low and high end bracket the measured number.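

In this assay, bromo in place of hydrogen on an aromatic carbon gives no change at the digits printed from compound 2 to compound 4 (within the scatter), after a number 0.18 log units higher from compound 1 to compound 3 (within the scatter) on the other core. Both steps lie within the usual scatter, so on these two cores the change cannot be told apart from no change at all, and this is as far as the pairs go: they do not show that the same would hold on a further core. Nothing shown here explains the result.

The compounds shown leave open what a different group at this place, such as an amine, a carboxylic acid or a longer chain, would do on either core. They also leave open whether a step beyond the scatter can arise here at all.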